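The source may hold more compounds than are shown below. What is called first, only, known or untested is meant among the compounds shown, and "the series" means these compounds.

Measured compounds:
Compound 1 `C[Se]/C(=N\C(=O)c1ccco1)NC(=O)c1ccco1`: 8780 nM
Compound 2 `C[Se]/C(=N\C(=O)c1cnc2ccccc2c1)NC(=O)c1cnc2ccccc2c1`: 3800 nM

Both compounds were tested in a functional assay on K562 cells (Homo sapiens) for cytotoxicity, read by MTT assay, with a stated time of 72 h; on this read-out lower numbers stand for stronger inhibition of growth and higher numbers for weaker inhibition of growth. Compound 1 gives 8780 nM, while compound 2 gives 3800 nM. Compound 2 thus has the lowest number of the two, and its nearest neighbour, compound 1, sits at a higher number by a gap beyond the usual scatter. Among the compounds with values here, the two compounds share a shared core but differ in more than one place, so their values show only that compound 2 inhibits growth more strongly; no single step between them can be named.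

Compound 3 `O=C(/N=C(/NC(=O)c1cnc2ccccc2c1)[Se]Cc1ccccc1)c1cnc2ccccc2c1` is the next compound. It differs from compound 2 in one place: phenyl in place of hydrogen on a saturated chain carbon bound to a selenium atom. Seen one bond further out, the change reads methyl to benzyl. No measured pair shows a change of this kind in this assay, so the data give no guide to its size. The step from compound 2 to compound 3 is expected to be a 1.3-fold lower number from compound 2 to compound 3 (0.10 log units; within the scatter) in this assay, a change not clearly beyond the scatter. Compound 3 is therefore estimated at 3000 nM, within a range from 800 nM to 12000 nM.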

Compound 3, concentration for 50% growth inhibition: 29300 nM
Estimate against measurement, compound 3: 9.8-fold (0.99 log units) below; the measured number lies above the stated range.
By their numbers in this assay, from the lowest: compound 2; then compound 1; then compound 3.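

The group on the selenium atom is not a silent position in this assay: going from methyl to benzyl, that is, phenyl in place of hydrogen on a saturated chain carbon bound to a selenium atom, gives a 7.7-fold higher number from compound 2 to compound 3 (0.89 log units; beyond the scatter). This step lies beyond the usual scatter and means clearly weaker inhibition of growth, which the earlier pair could not reveal, since compound 1 and compound 2 differ in more than one place and say nothing about this position alone. Nothing shown here offers a reason for the loss.

The compounds shown carry only methyl and benzyl on the selenium atom, so it remains open how the number would respond to an ethyl group, a longer chain without the phenyl ring, or a chain ending in an amine or a carboxylic acid. On these data alone, the change is also seen only once, on the core of compound 2, so whether benzyl would weaken growth inhibition on the core of compound 1 remains unknown.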